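The compounds below may be only part of what the source reports. "The series", "measured", "known", "first", "only" and "open" are said of these compounds alone.

Measured so far in an assay on HEK293 cells for agonist activity at transient receptor potential cation channel subfamily M member 8 (Homo sapiens), read by fluorescence and calcium flux, with a stated time of 15 min; a higher number here means that more compound is needed for the effect, a lower number that less compound is needed:
compound 1 `Cc1ccc(OCC(=O)N(Cc2cccs2)c2cccnc2)cc1`: 198 nM
compound 2 `CCN(C(=O)COc1ccc(C)cc1)C(C)c1cccs1`: "not active" (no number reported)
compound 3 `CCN(Cc1ccsc1)C(=O)COc1ccc(C)cc1`: 88 nM

Of the two numbers available, compound 1 stands highest; compound 3 gives the lower number, and that gap lies beyond the usual scatter. Compound 2 returns no number in this assay and is recorded as not active. Compound 4 `Cc1ccc(OCC(=O)N(C)Cc2cccs2)cc1` is not yet measured. Among the measured compounds shown here, it differs from compound 1 as follows: methyl in place of pyridin-3-yl on an amide-type nitrogen No pair of measured compounds isolates this change. Compound 3, which also lacks the pyridin-3-yl on the amide-type nitrogen, gives 88 nM, so a move toward a lower number is expected, of a size barely beyond the scatter. The expected step is a 1.7-fold lower number from compound 1 to compound 4 (0.22 log units; within the scatter). Compound 4 is estimated at 120 nM, with a range of 40 nM to 400 nM.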

Compound 4, half-maximal effective concentration: 400 nM
Beside the measured number, compound 4's estimate is 3.3-fold (0.52 log units) below it, and the stated range covers the measured number.
By their numbers in this assay, from the lowest: compound 3; then compound 1; then compound 4.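

In this assay, methyl in place of pyridin-3-yl on the amide-type nitrogen gives a 2.0-fold higher number from compound 1 to compound 4 (0.31 log units; beyond the scatter), a modest step and the only one in the series that isolates a single change. Compound 4 still returns a number, so activity in this assay does not depend on the pyridin-3-yl at this nitrogen, and the smaller methyl brings no gain here. On these data alone, whether an amine, a carboxylic acid or a longer chain carrying a hydroxyl group at this nitrogen would shift the number remains open. No measured property bears on this step, so the data give no explanation for it.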